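This account rests on a few compounds, and the source may have more. Where it says the series, first, only, none or still open, it means among the compounds named here.

Among the compounds with values here, in an ADME assay on NIH3T3 cells (Mus musculus) for cytotoxicity, read by MTT assay (a higher number here means a weaker inhibitor, a lower number a stronger inhibitor), compound 1 `N#Cc1c(-c2cccc(F)c2)c(C#N)c(=O)n(/N=C/c2cn(-c3ccccc3)nc2-c2ccccc2)c1N` gives 154 ug/mL and compound 2 `Cc1ccc(-c2c(C#N)c(N)n(/N=C/c3cn(-c4ccccc4)nc3-c3ccccc3)c(=O)c2C#N)cc1` gives 98 ug/mL, so compound 1 stands level with its only measured neighbour. Compound 3 `N#Cc1c(-c2ccc([N+](=O)[O-])cc2)c(C#N)c(=O)n(/N=C/c2cn(-c3ccccc3)nc2-c2ccccc2)c1N` differs from compound 1 by 4-methylphenyl's counterpart at the same aromatic carbon, a 4-nitrophenyl in place of 3-fluorophenyl on an aromatic carbon. Within the data shown here, the one measured step at this carbon, a 1.6-fold lower number from compound 1 to compound 2 (0.20 log units; within the scatter), is a thin basis, and it gives no reason to expect a step beyond the scatter in this assay, in either direction. The expected change is a 1.2-fold lower number from compound 1 to compound 3 (0.09 log units; within the scatter). The estimated value for compound 3 is 125 ug/mL, with an expected range of 65 ug/mL to 240 ug/mL.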

Compound 3, half-maximal inhibitory concentration: 84 ug/mL
Compound 3: the middle estimate sits 1.5-fold (0.17 log units) above what was measured; the measured number falls inside the stated range.
By their numbers in this assay, from the lowest: compounds 3, 2 and 1 (each within the scatter of the next).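

Replacing the aryl group at the carbon opposite the ring nitrogen with 4-nitrophenyl gives a 1.8-fold lower number from compound 1 to compound 3 (0.26 log units; within the scatter) and a 1.2-fold lower number from compound 2 to compound 3 (0.07 log units; within the scatter) in this assay without leaving the scatter. Three phenyl groups with different substituents at different ring positions, fluoro, methyl and nitro, therefore read alike at this carbon, including the direct exchange of methyl for nitro. Nothing available explains this flatness.

Still open, as far as these compounds go, is whether a primary amine or a carboxylic acid on this phenyl ring would give a step beyond the scatter. The same question stands for a saturated alkyl chain replacing the phenyl ring.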